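This account rests on a few compounds, and the source may have more. Where it says the series, first, only, none or still open, it means among the compounds named here.

Measured so far in a functional assay on HBL-100 cells (Homo sapiens) for antiproliferative activity, read by sulforhodamine B assay, with a stated time of 48 h; on this read-out higher numbers stand for weaker inhibition of growth and lower numbers for stronger inhibition of growth:

Compound 1 `COc1cc(-c2nc(CO[C@@H]3O[C@H](CSc4ncn[nH]4)[C@H]4OC5(CCCC5)O[C@@H]34)no2)cc(OC)c1OC`, 34000 nM.
Compound 2 `CC(=O)OC[C@H]1O[C@@H](OCc2noc(-c3ccc([N+](=O)[O-])cc3)n2)[C@@H]2OC3(CCCC3)O[C@@H]21`, 23000 nM.
Compound 3 `COc1cc(-c2nc(CO[C@@H]3O[C@H](CSc4nnc(N)s4)[C@H]4OC5(CCCC5)O[C@@H]34)no2)cc(OC)c1OC`, 33000 nM.

Compound 1 carries the highest of the three numbers, but its nearest neighbour, compound 3, and its furthest, compound 2, both lie within the scatter of it, so the three values are not told apart by this assay.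

The unmeasured compound 4 `Clc1ccc(-c2nc(CO[C@@H]3O[C@H](CSc4ncn[nH]4)[C@H]4OC5(CCCC5)O[C@@H]34)no2)cc1` arises from compound 1 by a single change, (4-chlorophenyl in place of 3,4,5-trimethoxyphenyl on an aromatic carbon). For the measured compounds named here, no measured step touches that part of the molecule. Going by the values given here, the only measured step, a 1.0-fold lower number from compound 1 to compound 3 (0.01 log units; within the scatter), concerns a group on the sulfur at the other end of the shared core and shows no movement beyond the scatter. Compound 2, which carries a differently substituted phenyl ring on the same five-membered ring together with a different group on the sugar, gives a value that sits within the scatter of compound 1, so the aryl change there was not seen to move the number either.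

On this basis a step from compound 1 to compound 4 of no more than the scatter is expected, without a direction. Compound 4 is therefore estimated at 30000 nM, with a range from 10000 nM to 90000 nM, which amounts to an expected step of a 1.1-fold lower number from compound 1 to compound 4 (0.05 log units; within the scatter).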

Compound 4, concentration for 50% growth inhibition: 24000 nM
Compound 4: middle estimate off by 1.3-fold (0.10 log units), on the high side, and the stated range covers the measured number.
By their numbers in this assay, from the lowest: compounds 2, 4, 3 and 1 (each within the scatter of the next).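

For the compounds shown here, until now, no step among the compounds isolated the aryl group on the five-membered aromatic ring with 2 nitrogen and 1 oxygen, as compound 2 also differs on the sugar. In this assay, going by these compounds alone, the exchange of 3,4,5-trimethoxyphenyl for 4-chlorophenyl at this place gives a 1.4-fold lower number from compound 1 to compound 4 (0.15 log units; within the scatter) as the first reading of this position alone. The number thus shows no movement beyond the scatter, even though the group that leaves has 12 heavy atoms and 3 hydrogen-bond acceptors and the group that enters has 7 heavy atoms and 0 hydrogen-bond acceptors, and no information on hand offers a reason for this result.

From the compounds shown here alone, both groups compared at this place are substituted phenyl rings, so it remains open whether an amine or a carboxylic acid on that phenyl ring, or a longer alkyl chain in place of the ring, would move the number beyond the scatter. Going by these compounds, it also remains open whether 4-chlorophenyl would give a similar reading with the 5-amino-1,3,4-thiadiazol-2-yl group of compound 3 on the sulfur.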